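The compounds below may be only part of what the source reports. "The series", "measured", "known", "first", "only" and "open" are said of these compounds alone.

Within the data shown here, compound 2 `Cc1ccc(=O)n(CC(=N)S)n1` is one of two compounds tested so far. In a functional assay on the whole organism (stomach) with Rattus norvegicus as the target (a lower number here means that less compound is needed, a higher number that more compound is needed for the effect), compound 2 gives only the limit > 100 mg/kg, not a number. Compound 1 `CC(Cn1ncccc1=O)C(=N)S` also gives the limit > 100 mg/kg in this assay. Both results therefore sit at the same limit (the limit of > 100 mg/kg in this assay, at which 2 of the 2 values shown sit). Compound 3 `Cc1ccc(=O)n(CCC(=N)S)n1` differs from compound 2 by a group of 4 heavy atoms (2 carbon, 1 nitrogen, 1 sulfur; no ring) in place of a group of 3 heavy atoms (1 carbon, 1 nitrogen, 1 sulfur; no ring), on a saturated chain carbon bound to an aromatic nitrogen, a group of 4 heavy atoms in place of a group of 3, on a saturated chain carbon bound to an aromatic nitrogen. Among the measured compounds shown here, with no measured step to lean on, no shift beyond the scatter is expected in this assay. The expected step is a step that the limit leaves unreadable from compound 2 to compound 3. Compound 3 is estimated at 150 mg/kg, between 40 mg/kg and 600 mg/kg, most likely again reported only as a limit.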

Compound 3, dose for half-maximal effect: 43.2 mg/kg
Compound 3: the middle estimate sits 3.5-fold (0.54 log units) above what was measured; measured number inside the range.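

In this assay, the change on a saturated chain carbon bound to an aromatic nitrogen gives an at least 2.3-fold lower number from compound 2 to compound 3 (0.36 log units; beyond the scatter). Among these compounds, this is the first result that is a number rather than a limit, so this position does respond to a group of 4 heavy atoms in place of a group of 3. The full size of the step stays unknown because compound 2 gives only a limit: the limit of > 100 mg/kg in this assay, at which 2 of the 3 values shown sit.

On these data alone, whether a longer chain would lower the number further remains open. So does the outcome with an amine or a carboxylic acid at this position.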